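Bromo for methoxy on a triazole-linked aryl group

A few compounds are considered here, and "the series" means these few. Any claim that something is new, unique, unknown or untested is made for them only; others in the source may bear on it.

Compound 1 `COc1ccc(-c2cn(C[C@H]3c4c(ccc(OS(=O)(=O)c5ccc(C)cc5)c4C)[C@@H]4CC[C@@]5(C)C[C@]43CC5=O)nn2)cc1` and compound 2 `Cc1ccc(S(=O)(=O)Oc2ccc3c(c2C)[C@H](Cn2cc(-c4ccc(Br)cc4)nn2)[C@@]24CC(=O)[C@@](C)(CC[C@@H]32)C4)cc1` share one core, while compound 3 `C=C1C(=O)[C@]23C[C@@]1(O)CC[C@H]2c1ccc(O)c(C)c1[C@@H]3Cn1cc(-c2ccc(OC)cc2)nn1` is built on a second core; the difference between the two cores is not broken down here. The pair in hand for compound 3 is compound 4 `C=C1C(=O)[C@]23C[C@@]1(O)CC[C@H]2c1ccc(O)c(C)c1[C@@H]3Cn1cc(-c2ccc(Br)cc2)nn1`, which has not yet been measured.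

In a functional assay on HL-60 cells (Homo sapiens) for cytotoxicity, read by MTT assay, with a stated time of 4 days (on this read-out lower numbers stand for stronger inhibition and higher numbers for weaker inhibition), compound 1 gives a limit rather than a number, > 20000 nM. Compound 2 also gives only a limit, > 20000 nM. The step that the two limits leave unreadable from compound 1 to compound 2 therefore cannot be read, since it rests on (the limit of > 20000 nM in this assay, at which 2 of the 3 values shown sit). The change behind it is bromo in place of methoxy on an aromatic carbon.

Compound 3, on the other core, gives a number in this assay, 1150 nM. The change from compound 3 to compound 4 is bromo in place of methoxy on an aromatic carbon, the same change as between compound 1 and compound 2, made at a place described in the same words.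

Among the measured compounds shown here, because the only measured instance of this change ends at the limit of > 20000 nM in this assay, at which 2 of the 3 values shown sit, it offers no size to carry over, and the expectation for compound 4 rests on compound 3 alone. The step of a 1.3-fold higher number from compound 3 to compound 4 (0.12 log units; within the scatter) is expected to stay within the usual scatter, with the value of compound 3 as anchor. Compound 4 is accordingly estimated at 1500 nM, with a plausible range from 500 nM to 5000 nM.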

Compound 4, half-maximal inhibitory concentration: 560 nM
Compound 4: middle estimate off by 2.7-fold (0.43 log units), on the high side; the range from low to high includes it.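

On the core of compound 3, in this assay, 4-methoxyphenyl to 4-bromophenyl gives a 2.1-fold lower number from compound 3 to compound 4 (0.31 log units; beyond the scatter), so on this core the bromo compound is modestly the stronger of the two. On the core of compound 1, the same change cannot be read, as compound 1 and compound 2 both stand at a limit and neither gives a number, so nothing shows whether the size or even the direction of the step carries from one core to the other: the limit of > 20000 nM in this assay, at which 2 of the 4 values shown sit. The series therefore holds one readable instance of this change, on one core, which is not enough to set a rule for the change or to give it a size that transfers to other cores.

The compounds shown hold only methoxy and bromo para to the large group on this aromatic ring, so it remains open whether the step on the core of compound 3 extends to other groups at that place, such as chloro, nitrile, an amine or a carboxylic acid. Also open, on these data alone, is how such a group would read on the core of compound 1 if a compound there gave a number rather than a limit in this assay.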